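Lengthening the chain toward the chlorophenoxy group in compound 3

The source may hold more compounds than are shown below. What is called first, only, known or untested is meant among the compounds shown, and "the series" means these compounds.

The measured compounds and their values:
Compound 1 `N#C/N=C1\N(CCCCCOc2ccc(Cl)cc2)C(=O)CN1c1ccncc1`: 2760 nM
Compound 2 `N#C/N=C1\N(CCCCCCOc2ccc(Cl)cc2)C(=O)CN1c1ccncc1`: 386 nM
Compound 3 `CC1C(=O)N(CCCCCOc2ccc(Cl)cc2)/C(=N\C#N)N1c1ccncc1`: 1780 nM

These three compounds share one core and were tested in a functional assay on NUGC cells (stomach, Homo sapiens) for cytotoxicity; a lower number here means a stronger inhibitor, a higher number a weaker inhibitor. Compound 3 gives 1780 nM, which lies close to the number for compound 1; the two are within the usual scatter of each other, so nothing separates them. Compound 2, by contrast, gives a number well apart from compound 3, with a clearly lower value in this assay.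

Compound 4 `CC1C(=O)N(CCCCCCOc2ccc(Cl)cc2)/C(=N\C#N)N1c1ccncc1` has not yet been measured. It differs from compound 3 in one place: (4-chlorophenoxy)methyl in place of 4-chlorophenoxy on a saturated chain carbon, five bonds along the chain from an amide-type nitrogen in a ring. The same change has been made once before among the measured compounds, in the pair without the methyl on the saturated ring carbon: a 7.2-fold lower number from compound 1 to compound 2 (0.85 log units; beyond the scatter). That step is well beyond the scatter, and the methyl itself made little difference, since a 1.6-fold lower number from compound 1 to compound 3 (0.19 log units; within the scatter). For the measured compounds named here, with only this one precedent, the change from compound 3 to compound 4 is expected to follow the same direction and roughly the same size, giving a 7.1-fold lower number from compound 3 to compound 4 (0.85 log units; beyond the scatter). Compound 4 is therefore estimated at 250 nM in this assay, with a likely range from 100 nM to 650 nM.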

Compound 4, half-maximal inhibitory concentration: 214 nM
Compound 4: middle estimate off by 1.2-fold (0.07 log units), on the high side; low and high end bracket the measured number.
By their numbers in this assay, from the lowest: compounds 4 and 2 (each within the scatter of the next); then compounds 3 and 1 (each within the scatter of the next).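

In this assay, the change from 4-chlorophenoxy to (4-chlorophenoxy)methyl on this saturated chain carbon gives an 8.3-fold lower number from compound 3 to compound 4 (0.92 log units; beyond the scatter), so the drop in the number is no longer tied to a single core and also holds with the methyl on the saturated ring carbon: the same change on two cores in this assay, a 7.2-fold lower number (0.85 log units; beyond the scatter) from compound 1 to compound 2 and an 8.3-fold lower number (0.92 log units; beyond the scatter) from compound 3 to compound 4, 1.2-fold (0.07 log units) apart, within the scatter of two such steps. The methyl in place of hydrogen gives a 1.8-fold lower number from compound 2 to compound 4 (0.26 log units; within the scatter), which stays within the scatter as it did in the earlier pair, so the methyl again separates nothing at the second chain form: the same change on two cores in this assay, a 1.6-fold lower number (0.19 log units; within the scatter) from compound 1 to compound 3 and a 1.8-fold lower number (0.26 log units; within the scatter) from compound 2 to compound 4, 1.2-fold (0.07 log units) apart, within the scatter of two such steps. Across these four compounds, the two changes therefore behave as if independent, with the step at each place about the same whichever form the other place takes, and no compound here goes against this.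

From the compounds shown here alone, it remains open whether the number keeps falling with 2-(4-chlorophenoxy)ethyl or a longer chain still, or whether there is a chain length beyond which it rises again. Going by these compounds, it is also open whether a larger group than methyl on the saturated ring carbon, such as ethyl or benzyl, would move the number beyond the scatter.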